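The compounds below may be only part of what the source reports. "The series", "measured", "known", "first", "only" and "open" are said of these compounds alone.

Within the data shown here, compound 1 `N#Cc1cnc(NC(=O)CCCOc2ccccc2)s1` is the only member of the series with a readable number in a physicochemical assay for solubility, read by nephelometry, in phosphate buffer, at pH 6.5 (a lower number here means a less soluble compound, a higher number a more soluble compound), where compound 1 gives 1100 nM. Compound 2 `Cc1cnc(NC(=O)CCCOc2ccccc2)s1` reads < 1100 nM, which is a limit of the assay. Compound 3 `O=C(CCCOc1ccccc1)Nc1ncc(Cl)s1` reads < 1200 nM, which is also a limit. The value of compound 1 is therefore the sole numerical reference point in the series.

Compound 4 `N#Cc1cnc(NC(=O)CCCOc2cccc(Cl)c2)s1` keeps the core of compound 1 and differs from it as follows: chloro in place of hydrogen on an aromatic carbon. In words, this is chloro in place of hydrogen on an aromatic carbon, taking phenyl to 3-chlorophenyl.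

The measured steps are a number no higher from compound 1 to compound 2 (the limit leaves the size open), a step that the limit leaves unreadable from compound 1 to compound 3 and a step that the two limits leave unreadable from compound 2 to compound 3. All three replace the group at the cyano position of compound 1, and none touches the phenyl, so they bear on the new change only indirectly. None has a readable size to carry over. Among the measured compounds shown here, their only guide is the first step, which points no higher in this assay.

The expectation is therefore a small downward move that stays within the scatter, and the estimated step is a 1.7-fold lower number from compound 1 to compound 4 (0.23 log units; within the scatter). A limit rather than a number is also a likely outcome. For compound 4 the estimated value is 650 nM, with an expected range of 250 nM to 1500 nM.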

Compound 4, solubility: < 1600 nM
Compound 4: only a limit was reported; the forecaster's own chance of this, stated with the estimate: 70%; the middle value is on the limit's open side.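

In this assay compound 4 gives < 1600 nM, which is a limit and not a number. Among these compounds, no step from compound 1 to compound 4 can be read. The compounds shown leave open whether chloro in place of hydrogen, taking phenyl to 3-chlorophenyl, shifts the read-out in this assay, in which direction and by how much.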